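The source may hold more compounds than are shown below. What is called first, only, known or untested is meant among the compounds shown, and "the series" means these compounds.

In a functional assay on SW-620 cells (Homo sapiens) for antiproliferative activity, read by MTT assay, with a stated time of 24 h (on this read-out higher numbers stand for weaker inhibition and lower numbers for stronger inhibition), compound 1 `COc1ccc(C(=O)/C=C/c2cc(OC)c(OC)c(OC)c2)c2c1C=CC(C)(C)O2` gives 9150 nM, the only result in this small set that is reported as a number. Compound 2 `COc1ccc(C(=O)/C=C/c2ccc(-c3ccccc3)cc2)c2c1C=CC(C)(C)O2` reaches only the limit of the assay, > 10000 nM, so for it no number is known. Compound 3 `COc1ccccc1/C=C/C(=O)c1ccc(OC)c2c1OC(C)(C)C=C2` likewise ends at the limit of the assay, > 10000 nM. Going by the values given here, two of the three measured compounds thus sit at the limit of > 10000 nM in this assay, at which 2 of the 3 values shown sit, and compound 1 stands on its own as the one with a measured number; whether it truly separates from the other two cannot be told from a limit.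

Compound 4 `COc1cc(/C=C/C(=O)c2ccc(OC)c3c2OC(C)(C)C=C3)cc(OC)c1O` has not yet been measured. It differs from compound 1 in one place: hydrogen in place of methyl on an oxygen on an aromatic ring, which cut one bond further out reads as methoxy to hydroxy. Among the compounds with values here, no step between two measured compounds follows this change, so no measured size can be carried across. The expectation is a step from compound 1 to compound 4 of a 1.0-fold lower number from compound 1 to compound 4 (0.01 log units; within the scatter), most likely not beyond the usual scatter in either direction. On that basis compound 4 is estimated at 9000 nM in this assay, with a range from 3000 nM to 30000 nM, and a limit rather than a number remains a real possibility for compound 4 as well.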

Compound 4, half-maximal inhibitory concentration: > 10000 nM
Compound 4: only a limit was reported; the forecaster's own chance of this, stated with the estimate: 45%; middle value at least 1.1-fold (0.04 log units) away from the limit.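

In this assay, going by these compounds alone, the change from methoxy to hydroxy on an oxygen on an aromatic ring gives an at least 1.0-fold higher number from compound 1 to compound 4 (0.03 log units; that floor lies within the scatter), the first step in this set between two measured compounds that differ in one place. The value of compound 4 is a limit and not a number, so this step is only a floor, and the true gap could be small or much larger. The hydrogen in place of methyl at this position therefore brings no measurable gain in this assay, and compound 4 joins the group of compounds that end at the limit: the limit of > 10000 nM in this assay, at which 3 of the 4 values shown sit.

The compounds shown leave open whether a longer chain on this oxygen, such as ethyl, or an amine in place of the hydroxy would bring a number clearly away from the limit. Also open, on these data alone, is how far past the limit compound 2, compound 3 and compound 4 really lie, so no order among them can be read, and it remains unknown whether any of them truly separates from compound 1.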